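The source may report more compounds than this note shows. Statements on the series, on what has been measured and on what is new or still open speak of the compounds shown alone.

In an ADME assay on MRC5 cells (Homo sapiens) for cytotoxicity, read by fluorescence and resazurin assay, with a stated time of 3 days (a lower number here means a stronger inhibitor, a higher number a weaker inhibitor), compound 1 (`Cc1ccc(Oc2cccc(CN3CCC(n4cc(C)c(=O)[nH]c4=O)CC3)c2)cc1`) reads > 64000 nM, which is a limit of the assay. Compound 2 (`Cc1cn(C2CCN(Cc3cccc(Oc4cccc(F)c4)c3)CC2)c(=O)[nH]c1=O`) reads > 64000 nM, again a limit. For the measured compounds named here, compound 3 (`COc1ccc(Oc2cccc(CN3CCC(n4cc(C)c(=O)[nH]c4=O)CC3)c2)cc1`) gives 28000 nM, the only actual number of the three. Two measured steps lead to compound 3 and both are at least modest: an at least 2.2-fold lower number from compound 1 to compound 3 (0.35 log units; beyond the scatter), and an at least 2.2-fold lower number from compound 2 to compound 3 (0.35 log units; beyond the scatter). The step that the two limits leave unreadable from compound 1 to compound 2 adds nothing on size.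

Compound 4 (`Cc1cn(C2CCN(Cc3cccc(Oc4ccccn4)c3)CC2)c(=O)[nH]c1=O`) carries pyridin-2-yl in place of 4-methoxyphenyl on an oxygen on an aromatic ring. This removes the 4-methoxyphenyl that only compound 3 carries, so the change runs against the direction of an at least 2.2-fold lower number from compound 2 to compound 3 (0.35 log units; beyond the scatter), and a higher number is expected in this assay. The expected move is a 2.1-fold higher number from compound 3 to compound 4 (0.33 log units; beyond the scatter). For compound 4 the estimate is 60000 nM, with an expected range from 25000 nM to 110000 nM. The reading may also return only as the limit of > 64000 nM in this assay, at which 2 of the 3 values shown sit.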

Compound 4, half-maximal inhibitory concentration: > 64000 nM
Compound 4: no number, only a limit; the forecaster's own chance of this, stated with the estimate: 55%; at least 1.0-fold (0.02 log units) between middle value and limit.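

In this assay, pyridin-2-yl in place of 4-methoxyphenyl on an oxygen on an aromatic ring gives an at least 2.2-fold higher number from compound 3 to compound 4 (0.35 log units; beyond the scatter), so a second kind of replacement for the 4-methoxyphenyl, this time a ring with a hetero atom, also raises the number. Of the four groups now shown on this oxygen, 4-methoxyphenyl is the only one that gives an actual number. Compound 4 gives > 64000 nM, which is a limit of the assay, and its reading joins the group at: the limit of > 64000 nM in this assay, at which 3 of the 4 values shown sit. The steps from compound 1 and from compound 2 to compound 4 cannot be read.

From the compounds shown here alone, whether a 4-ethoxyphenyl or a 4-aminophenyl on this oxygen would also give an actual number stays open. So does whether a pyridin-3-yl there would read as pyridin-2-yl does.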